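This account rests on a few compounds, and the source may have more. Where it says the series, first, only, none or still open, it means among the compounds named here.

In a functional assay on HeLa cells (Homo sapiens) for inhibition, read by MTT assay, with a stated time of 4 days (on this read-out higher numbers stand for weaker inhibition and lower numbers for stronger inhibition), compound 2 `COc1cc(NC(C)CCCNC(=O)NN)c2ncccc2c1` gives >= 250000 nM, which is a limit of the assay and not a number. Two larger relatives do give numbers: compound 1 `COc1ccc(C(=NNC(=O)NNC(=O)NCCCC(C)Nc2cc(OC)cc3cccnc23)c2ccc(OC)cc2)cc1` gives 50000 nM and compound 3 `COc1ccc(/C(=N/NC(=O)NCCCC(C)Nc2cc(OC)cc3cccnc23)c2ccccc2)cc1` gives 129000 nM. Compound 4 `COc1cc(NC(C)CCCNC(=O)NNC(=O)NCCCO)c2ncccc2c1` is built from compound 2 by placing (3-hydroxypropyl)carbamoyl in place of hydrogen on an amine nitrogen whose other neighbour is an amide-type nitrogen: (3-hydroxypropyl)carbamoyl in place of hydrogen on an amine nitrogen. Among the compounds with values here, no measured pair shows this change, so the expectation in this assay is only a modest move toward stronger inhibition, resting on the numbers of those two larger relatives. The expected change is an at least 1.3-fold lower number from compound 2 to compound 4 (0.14 log units; that floor lies within the scatter). Compound 4 is estimated at about 180000 nM, with an expected range from 70000 nM to 300000 nM.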

Compound 4, half-maximal inhibitory concentration: > 250000 nM
Compound 4: only a limit was reported (the forecaster's own chance of this, stated with the estimate: 45%); middle value at least 1.3-fold (0.14 log units) from the limit.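

Compound 2 and compound 4 each give only a limit and not a number, so the step between them cannot be read. As far as these compounds go, whether (3-hydroxypropyl)carbamoyl changes inhibition at all, in either direction, stays open.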